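Methoxycarbonyl in place of pyridin-3-yl: working notes

The source may hold more compounds than are shown below. What is called first, only, known or untested is meant among the compounds shown, and "the series" means these compounds.

In an ADME assay on S9 fraction from liver (Rattus norvegicus) for metabolic stability, read by LC-MS, using NADPH, with a stated time of 30 min (on this read-out lower numbers stand for a less stable compound and higher numbers for a more stable compound), compound 1 `CCCCCCCCc1ccc(OCC(=O)Cn2nnnc2-c2ccc(Cl)cc2)cc1` gives 45% and compound 2 `CCCCCCCCc1ccc(OCC(=O)Cn2nnnc2-c2cccc(Cl)c2)cc1` gives 41%, and a number 4 percentage points lower from compound 1 to compound 2 (within the scatter) is no real separation. Compound 3 `CCCCCCCCc1ccc(OCC(=O)Cn2nnnc2-c2cccnc2)cc1`, at 20%, holds the lowest of the three numbers, with a number 25 percentage points lower from compound 1 to compound 3 (beyond the scatter) and a number 21 percentage points lower from compound 2 to compound 3 (beyond the scatter).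

Compound 4 `CCCCCCCCc1ccc(OCC(=O)Cn2nnnc2C(=O)OC)cc1` carries methoxycarbonyl in place of pyridin-3-yl on an aromatic carbon. The three measured steps all fall at this carbon, but each exchanges one aromatic ring for another. None shows what happens when the ring is lost, so they guide the size of the step only loosely. The two modest steps suggest that changes here can move this assay noticeably, in either direction if read in reverse. With compound 3 at 20%, little room remains downward.

The expected change is small and slightly downward, a number 5 percentage points lower from compound 3 to compound 4 (within the scatter), and it is not expected to pass the scatter. For compound 4 the estimate is 15%, with an expected range from 3% to 38%.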

Compound 4, percent of the compound remaining: 38%
Compound 4: the middle estimate sits 23 percentage points below what was measured; measured number inside the range.
By their numbers in this assay, from the lowest: compound 3; then compounds 4, 2 and 1 (each within the scatter of the next).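

Within the data shown here, compound 4 is the first here with no aromatic ring at this carbon, and a number 18 percentage points higher from compound 3 to compound 4 (beyond the scatter) in this assay shows that an aromatic ring at this place is not needed to reach the numbers of the chlorophenyl compounds. Both a number 3 percentage points lower from compound 2 to compound 4 (within the scatter) and a number 7 percentage points lower from compound 1 to compound 4 (within the scatter) leave methoxycarbonyl unseparated from the two chlorophenyl groups, so among these four groups only pyridin-3-yl stands apart. No evidence at hand gives a reason for these numbers.

Still open, on these data alone, is whether the carbonyl of methoxycarbonyl matters or any small group without a ring would serve equally well at this carbon. A primary amide, a carboxylic acid or a short alkyl chain here would help to separate these two readings.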